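The compounds below may be only part of what the source reports. "The series", "measured", "known", "first", "only" and "open" are said of these compounds alone.

Measured so far in a functional assay on MDA-MB-231 cells (Homo sapiens) for antiproliferative activity, read by MTT assay; a lower number here means a stronger inhibitor, a higher number a weaker inhibitor:
- compound 1 `CCCC/C=C\CCCCCCCCCc1cc(=O)c2c(O)c(C)c(OCOC)cc2o1`: > 87000 nM (a limit, not a number)
- compound 2 `CCCC/C=C\CCCCCCCCCc1cc(=O)c2c(O)c(C)c(OCOC)c(C)c2o1`: > 87000 nM (a limit, not a number)

Among the measured compounds shown here, compound 1 therefore stands only at a limit, and the series so far offers just (the limit of > 87000 nM in this assay, at which 2 of the 2 values shown sit).

The next compound is compound 3 `CCCC/C=C\CCCCCCCCCc1cc(=O)c2c(O)c(C)c(O)cc2o1`. The change is hydrogen in place of methoxymethyl on an oxygen on an aromatic ring, or methoxymethoxy to hydroxy.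

For the measured compounds named here, the only measured step is a step that the two limits leave unreadable from compound 1 to compound 2. It concerns a different place and gives no size to carry over. Compound 1 sits at > 87000 nM, so any readable step could only run towards a stronger inhibitor in this assay. A modest gain is expected, though a second limit remains quite possible.

The expected size, loosely estimated, is an at least 1.9-fold lower number from compound 1 to compound 3 (0.28 log units; that floor lies within the scatter). Compound 3 is estimated at 45000 nM, with an expected range of 12000 nM to 100000 nM.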

Compound 3, half-maximal inhibitory concentration: 42800 nM
Estimate against measurement, compound 3: 1.1-fold (0.02 log units) above, and the stated range covers the measured number.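

In this assay, among the compounds shown here, methoxymethoxy to hydroxy at this oxygen gives the first measured number, with an at least 2.0-fold lower number from compound 1 to compound 3 (0.30 log units; that floor lies within the scatter) as the readable step, and only the floor of that step is known. Compound 1 gives > 87000 nM, which is a limit and not a number. The hydroxy compound is therefore the only one shown with a number, while the other two remain at the limit: the limit of > 87000 nM in this assay, at which 2 of the 3 values shown sit.

On these data alone, whether the gain belongs to the hydroxy group itself or simply to the loss of methoxymethyl remains open, and a methyl or acetyl group on this oxygen would bear on that. Also open, as far as these compounds go, is whether methyl in place of hydrogen on the aromatic carbon gives a readable step once the hydroxy group is present.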